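This account rests on a few compounds, and the source may have more. Where it says the series, first, only, none or still open, it means among the compounds named here.

Measured compounds:
Compound 1, `O=C([C@H]1C[C@@H]1F)N1CC2CC(C1)N2`: 100%
Compound 2, `C[C@H]1C[C@H]1C(=O)N1CC2CC(C1)N2`: 93%

Both compounds were tested in an assay on SH-EP1 cells for agonist activity at Neuronal acetylcholine receptor; alpha4/beta2 (Homo sapiens), read by FLIPR and calcium flux; a lower number here means a smaller maximal response, a higher number a larger maximal response. Compound 1 gives 100%, and compound 2 gives 93%. Among the compounds with values here, the single measured step, a number 7 percentage points lower from compound 1 to compound 2 (within the scatter), replaces one small ring on the carbonyl carbon with another, and the two compounds lie within the scatter of each other. Compound 2 therefore holds the lower of the two numbers, but not by an amount that can be called a difference.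

Compound 3, `C[C@@H]1C[C@H]1C(=O)N1CC2CC(C1)N2`, has not yet been measured. Compared with compound 2 the change is: the two compounds have the same atoms and bonds; at least one stereo element is drawn with a configuration in one of them and without one in the other: 1 of 4 stereo elements differ; a stereocentre at a saturated ring carbon is drawn S in compound 2 and R in compound 3. Nothing leaves and nothing enters; only the drawn configuration at one saturated ring carbon differs.

Within the data shown here, no measured step concerns such a change in drawn configuration. Among the measured compounds shown here, the one step available, from compound 1 to compound 2, is a change of substituent and lies within the scatter, so it gives no guide to a direction. The expected step of a number 3 percentage points lower from compound 2 to compound 3 (within the scatter) is therefore none beyond the scatter. For compound 3 the expected value in this assay is 90%, with a range from 72% to 104%.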

Compound 3, largest response reached (Emax), in percent of the reference or control that the assay uses: 110%
The estimate for compound 3 lay 20 percentage points below the measured number; the measured number lies above the stated range.
By their numbers in this assay, from the lowest: compounds 2, 1 and 3 (each within the scatter of the next, the first and the last beyond it).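

Changing only the drawn configuration at one saturated ring carbon, from S to R, gives a number 17 percentage points higher from compound 2 to compound 3 (beyond the scatter) in this assay. This shows that the maximal response at this position can depend on the arrangement of the groups in space, even when the atoms and bonds stay the same, which the earlier substituent change could not show. Placing 2-methylcyclopropyl instead of 2-fluorocyclopropyl on the carbonyl carbon gives a number 10 percentage points higher from compound 1 to compound 3 (within the scatter), so of the steps shown, only the one in configuration goes beyond the scatter, and the only structural difference recorded for it is this: the fact that one of compounds 2 and 3 is drawn with a defined configuration and the other without, at the place where they differ.

The compounds shown do not tell whether the 2-fluorocyclopropyl group of compound 1 would respond in the same way to a change in configuration at the matching ring carbon. They also leave open how the response would change with an ethyl group, a hydroxymethyl group or an amine in place of the methyl on the cyclopropyl ring, and whether the effect of configuration would persist with those groups.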